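Acyl group changes on the carbonyl carbon: efficacy notes

A few compounds are considered here, and "the series" means these few. Any claim that something is new, unique, unknown or untested is made for them only; others in the source may bear on it.

Measured so far: compound 1, `Cc1nc(S(C)(=O)=O)ccc1Oc1ncnc(OC2CCN(C(=O)OC(C)(C)CF)CC2)c1F`, gives 95%; compound 2, `CCC(F)(F)C(=O)N1CCC(Oc2ncnc(Oc3ccc(S(C)(=O)=O)nc3C)c2F)CC1`, gives 90%.

Both compounds share one core and differ only in the group on the carbonyl carbon attached to the amide-type nitrogen in a ring. In a functional assay on isolated protein for inhibition of Glucose-dependent insulinotropic receptor (Rattus norvegicus), read by HTRF and cAMP accumulation (on this read-out lower numbers stand for smaller maximal responses and higher numbers for larger maximal responses), compound 1 gives 95% and compound 2 gives 90%. Within the data shown here, the single measured step, a number 5 percentage points lower from compound 1 to compound 2 (within the scatter), leaves the largest response within the scatter. Compound 2 has the lowest of the two numbers, with compound 1 the nearest, a number within the scatter of it, so no order between the two can be claimed.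

Compound 3, `Cc1nc(S(C)(=O)=O)ccc1Oc1ncnc(OC2CCN(C(=O)c3ncc(Cl)cn3)CC2)c1F`, is not yet measured. Its change from compound 2 is 5-chloropyrimidin-2-yl in place of 1,1-difluoropropyl on a carbonyl carbon. Among the measured compounds shown here, the only measured step that bears on this position is a number 5 percentage points lower from compound 1 to compound 2 (within the scatter), which stayed within the scatter; that step exchanged one open-chain group for another, whereas here a six-membered aromatic ring with two hetero atoms enters. On that single step, no change beyond the scatter in this assay is expected, and the step of no change at the digits printed from compound 2 to compound 3 (within the scatter) is estimated to be small. Compound 3 is expected to reach 90%, with a range from 75% to 102%.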

Compound 3, largest response reached (reported as efficacy), in percent of the reference or control that the assay uses: 77%
Compound 3: middle estimate off by 13 percentage points, on the high side, and the stated range covers the measured number.
By their numbers in this assay, from the lowest: compound 3; then compounds 2 and 1 (each within the scatter of the next).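

In this assay, the position on a carbonyl carbon whose other neighbours are amide-type nitrogen in a ring now shows a change beyond the scatter: 5-chloropyrimidin-2-yl in place of 1,1-difluoropropyl gives a number 13 percentage points lower from compound 2 to compound 3 (beyond the scatter), and the same ring group set against the open-chain group of compound 1 gives a number 18 percentage points lower from compound 1 to compound 3 (beyond the scatter). Within these three compounds, the two open-chain groups stay within the scatter of each other and the single ring-bearing group stands apart from both, so the largest response is not indifferent to this position, although both steps are modest and the response is lowered rather than lost. Nothing at hand explains the drop.

With a single ring-bearing group, the step cannot be divided among the aromatic ring, its two ring nitrogens and the chlorine; a plain phenyl or an unsubstituted pyrimidin-2-yl on the same carbonyl carbon would separate these parts. Also open, from the compounds shown here alone, is where a saturated ring such as cyclohexyl, or a longer chain, would fall relative to compound 2 and compound 3.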